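Swapping the pyrazole for a pyridine on the shared core

The source may report more compounds than this note shows. Statements on the series, on what has been measured and on what is new or still open speak of the compounds shown alone.

Measured so far:
- compound 1, `c1cc(-c2nccs2)c2c(c1)C(c1ncc[nH]1)CC2`: 64%
- compound 2, `CCS(=O)(=O)Nc1cccc2c1CCC2c1ncc[nH]1`: 86%
- compound 3, `Cn1cc(-c2cccc3c2CCC3c2ncc[nH]2)cn1`: 12%

All three compounds share one core and differ only in the group attached to an aromatic carbon of it. In a functional assay on CHO cells for agonist activity at Alpha-1A adrenergic receptor (Homo sapiens), read by FLIPR and calcium flux (on this read-out lower numbers stand for smaller maximal responses and higher numbers for larger maximal responses), compound 3 stands lowest of the three; compound 1 lies above it by a number 52 percentage points lower from compound 1 to compound 3 (beyond the scatter) reversed, and compound 2 by a number 74 percentage points lower from compound 2 to compound 3 (beyond the scatter) reversed, both gaps beyond the scatter.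

Compound 4, `c1ccc(-c2cccc3c2CCC3c2ncc[nH]2)nc1`, has not yet been measured. It differs from compound 3 in one place: pyridin-2-yl in place of 1-methyl-1H-pyrazol-4-yl on an aromatic carbon. Going by the values given here, the steps that bear on this are the two that lead into compound 3, a number 52 percentage points lower from compound 1 to compound 3 (beyond the scatter) and a number 74 percentage points lower from compound 2 to compound 3 (beyond the scatter). Each shows that replacing a one-ring aromatic or a sulfonylamino group by 1-methyl-1H-pyrazol-4-yl lowers the maximal response a great deal. Removing that pyrazolyl again and putting a pyridin-2-yl, a six-membered aromatic ring with one hetero atom, in its place is therefore expected to raise the response, most likely back toward the level of compound 1 whose 1,3-thiazol-2-yl is also a single aromatic ring with hetero atoms. The expected step is a number 43 percentage points higher from compound 3 to compound 4 (beyond the scatter). Compound 4 is estimated to give 55%, with a range from 30% to 80%.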

Compound 4, largest response reached (Emax), in percent of the reference or control that the assay uses: 53%
Estimate against measurement, compound 4: 2 percentage points above; measured number inside the range.
By their numbers in this assay, from the lowest: compound 3; then compound 4; then compound 1; then compound 2.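

In this assay, putting pyridin-2-yl in place of 1-methyl-1H-pyrazol-4-yl on this aromatic carbon gives a number 41 percentage points higher from compound 3 to compound 4 (beyond the scatter), even though both groups count 6 heavy atoms and each is a single aromatic ring. The low response of compound 3 therefore does not extend to every single aromatic ring at this position, and the choice of ring matters a great deal here. The new compound does not reach the other two, with a number 33 percentage points lower from compound 2 to compound 4 (beyond the scatter) and, as a modest step, a number 11 percentage points lower from compound 1 to compound 4 (beyond the scatter), so the (ethylsulfonyl)amino group still gives the largest response of the four, and nothing shown here explains why these groups differ.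

The compounds shown leave open whether the ring nitrogen of pyridin-2-yl matters, which a plain phenyl ring or a pyridin-3-yl group at the same position would help to test. They also leave open how groups of a different kind, such as an amine, a carboxylic acid or a longer alkyl chain, would behave on this aromatic carbon.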